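The source may hold more compounds than are shown below. What is called first, only, known or untested is meant among the compounds shown, and "the series" means these compounds.

Of the compounds shown here, three built on a shared core have been measured in an ADME assay on microsomes from liver (Homo sapiens) for metabolic stability, read by LC-MS, using NADPH, with a stated time of 60 min, tested at 1 uM; a lower number here means that the compound disappears faster, a higher number that the compound lasts longer. Compound 1 `CN(C)c1ccc(C2CCCN2Cc2ccc(-c3ccccc3[N+](=O)[O-])o2)cc1` gives 0.0423 h in this assay, compound 2 `O=[N+]([O-])c1ccccc1-c1ccc(CN2CCCC2c2ccc(N3CCCCC3)cc2)o1` gives 0.0325 h, and compound 3 `Cc1cc([N+](=O)[O-])ccc1-c1ccc(CN2CCCC2c2cccc(N(C)C)c2)o1` gives 0.0783 h. Compound 2 thus holds the lowest of the three numbers; its value and that of compound 1 lie within the usual scatter of each other, while compound 3 stands further off, beyond the scatter. Among the measured compounds shown here, the one measured step that touches the same aromatic carbon is a 1.3-fold lower number from compound 1 to compound 2 (0.11 log units; within the scatter). The unmeasured compound 4 `O=[N+]([O-])c1ccccc1-c1ccc(CN2CCCC2c2ccc(N3CCCC3)cc2)o1` differs from compound 2 in a single place: pyrrolidin-1-yl in place of piperidin-1-yl on an aromatic carbon. This change is of the same kind as the earlier one, exchanging one non-aromatic nitrogen ring for another on the same aromatic carbon, and that earlier step stayed within the scatter. The half-life of compound 4 in this assay is therefore expected to remain close to that of compound 2, with no step beyond the scatter, the expected step being a 1.1-fold higher number from compound 2 to compound 4 (0.03 log units; within the scatter). Compound 4 is estimated at 0.035 h, with a range from 0.018 h to 0.07 h.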

Compound 4, half-life: 0.169 h
Compound 4: the middle estimate sits 4.8-fold (0.68 log units) below what was measured; the measured number lies above the stated range.
By their numbers in this assay, from the lowest: compounds 2, 1 and 3 (each within the scatter of the next, the first and the last beyond it); then compound 4.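

In this assay, the aromatic carbon para to a large group proved sensitive to the group it carries: pyrrolidin-1-yl in place of piperidin-1-yl gives a 5.2-fold higher number from compound 2 to compound 4 (0.72 log units; beyond the scatter) and so sets the five-membered ring apart from the six-membered one. Pyrrolidin-1-yl in place of dimethylamino gives a 4.0-fold higher number from compound 1 to compound 4 (0.60 log units; beyond the scatter) in the same direction, whereas the earlier exchange of dimethylamino for piperidin-1-yl gave only a 1.3-fold lower number from compound 1 to compound 2 (0.11 log units; within the scatter) and had shown no such sensitivity. Nothing measured here accounts for this difference. The compounds shown do not tell whether the higher number is particular to pyrrolidin-1-yl or would extend to a smaller azetidine ring or a morpholine ring on this carbon. Going by these compounds, whether pyrrolidin-1-yl would give a similar step on the core of compound 3 also remains open.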